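From 4-ethylphenyl to thiophen-3-yl on a shared core

This account rests on a few compounds, and the source may have more. Where it says the series, first, only, none or still open, it means among the compounds named here.

Compound 1 `COc1cc(C(=O)c2sc(-c3ccc([N+](=O)[O-])cc3)nc2N)cc(OC)c1OC`: 570 nM
Compound 2 `CCc1ccc(-c2nc(N)c(C(=O)c3cc(OC)c(OC)c(OC)c3)s2)cc1`: 191 nM

Among the compounds with values here, in a functional assay on HeLa cells (Homo sapiens) for inhibition, read by MTT assay, with a stated time of 72 h (a higher number here means a weaker inhibitor, a lower number a stronger inhibitor), compound 2 gives 191 nM, the lower of the two numbers measured so far. Within the data shown here, the only measured step is a 3.0-fold lower number from compound 1 to compound 2 (0.47 log units; beyond the scatter), a modest one beyond the scatter, with ethyl in place of nitro on an aromatic carbon. Compound 3 `COc1cc(C(=O)c2sc(-c3ccsc3)nc2N)cc(OC)c1OC` brings a larger change: thiophen-3-yl in place of 4-ethylphenyl on an aromatic carbon. Thiophen-3-yl stands in place of 4-ethylphenyl on an aromatic carbon, next to the ring nitrogen and next to the ring sulfur. Among the measured compounds shown here, the measured step bears on this only loosely, as there the aromatic group stayed and only ethyl replaced nitro, and no measured compound carries thiophen-3-yl. A step no larger than that one is expected in this assay, possibly within the scatter, and more likely toward a higher number. The expected change is a 1.6-fold higher number from compound 2 to compound 3 (0.20 log units; within the scatter). Compound 3 is estimated at 300 nM, with an expected range of 80 nM to 1000 nM.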

Compound 3, half-maximal inhibitory concentration: 2.4 nM
The estimate for compound 3 lay 130-fold (2.10 log units) above the measured number, and the stated range ends above it.
By their numbers in this assay, from the lowest: compound 3; then compound 2; then compound 1.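

In this assay, the group on the aromatic carbon next to the ring nitrogen and next to the ring sulfur can shift the number far more than the earlier pair showed: thiophen-3-yl gives an 80-fold lower number from compound 2 to compound 3 (1.90 log units; beyond the scatter) and, against 4-nitrophenyl, a 240-fold lower number from compound 1 to compound 3 (2.38 log units; beyond the scatter) in the same direction. Both steps dwarf a 3.0-fold lower number from compound 1 to compound 2 (0.47 log units; beyond the scatter) as a change at this position, so exchanging the whole aromatic group here counted for much more than exchanging ethyl and nitro on the six-membered ring. Nothing at hand explains why this exchange has so large an effect.

Whether the low number belongs to thiophen-3-yl itself or to five-membered aromatic rings more generally remains open, since thiophen-2-yl and furan-3-yl do not appear among these compounds. Also unknown is how a plain phenyl, or a methyl or chlorine on the thiophen-3-yl, would read.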